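The source may hold more compounds than are shown below. What is called first, only, known or untested is meant among the compounds shown, and "the series" means these compounds.

In an ADME assay on the whole organism (Rattus norvegicus, strain Sprague-Dawley) for pharmacokinetics, read by LC-MS, at a dose of 5 mg/kg by the oral route (on this read-out higher numbers stand for higher exposure at the dose given and lower numbers for lower exposure), three compounds sharing one core have been measured. Compound 1 `Cc1nc(C)c([C@H](OC(C)(C)C)C(=O)O)c(N2CCC(C)(C)CC2)c1-c1ccc2c(c1)CCN(Cc1ccc(F)cc1F)C2` gives 4420 ng.h/mL, compound 2 `Cc1nc(C)c([C@H](OC(C)(C)C)C(=O)O)c(N2CCC(C)(C)CC2)c1-c1ccc2c(c1)CCN(c1ncnc3c1cnn3C)C2` gives 22100 ng.h/mL, and compound 3 `Cc1nc(C)c([C@H](OC(C)(C)C)C(=O)O)c(N2CCC(C)(C)CC2)c1-c1ccc2c(c1)CCN(c1nccc(-c3cnccn3)n1)C2` gives 15100 ng.h/mL. Compound 3 thus sits with compound 2 and apart from compound 1, as shown by a 1.5-fold lower number from compound 2 to compound 3 (0.17 log units; within the scatter) and a 3.4-fold higher number from compound 1 to compound 3 (0.53 log units; beyond the scatter).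

Compound 4 `Cc1nc(C)c([C@H](OC(C)(C)C)C(=O)O)c(N2CCC(C)(C)CC2)c1-c1ccc2c(c1)CCN(c1nc3cnccc3s1)C2` makes one change to compound 3: a group of 9 heavy atoms (6 carbon, 2 nitrogen, 1 sulfur; one five-membered aromatic ring with 2 hetero atoms, one six-membered aromatic ring with 1 hetero atom) in place of a group of 12 heavy atoms (8 carbon, 4 nitrogen; 2 six-membered aromatic rings with 2 hetero atoms each), on an amine nitrogen in a ring. The measured steps at this same amine nitrogen are a 5.0-fold higher number from compound 1 to compound 2 (0.70 log units; beyond the scatter), a 3.4-fold higher number from compound 1 to compound 3 (0.53 log units; beyond the scatter) and a 1.5-fold lower number from compound 2 to compound 3 (0.17 log units; within the scatter). The last is the closest guide, since compound 2 and compound 3 both carry hetero atoms in every aromatic ring of the group, as compound 4 does. No step beyond the scatter is therefore expected in this assay, and the expected step is a 1.3-fold lower number from compound 3 to compound 4 (0.10 log units; within the scatter). The estimate for compound 4 is 12000 ng.h/mL, within a range of 4500 ng.h/mL to 30000 ng.h/mL.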

Compound 4, area under the concentration-time curve: 6630 ng.h/mL
Compound 4: the middle estimate sits 1.8-fold (0.26 log units) above what was measured; measured number inside the range.
By their numbers in this assay, from the lowest: compounds 1 and 4 (each within the scatter of the next); then compounds 3 and 2 (each within the scatter of the next).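

In this assay the group with sulfur does not hold the level of the two all-nitrogen groups, with a 2.3-fold lower number from compound 3 to compound 4 (0.36 log units; beyond the scatter) and a 3.3-fold lower number from compound 2 to compound 4 (0.52 log units; beyond the scatter) while a 1.5-fold higher number from compound 1 to compound 4 (0.18 log units; within the scatter) places it with the fluorine-bearing group. Hetero atoms in every aromatic ring of the group are therefore not enough at this amine nitrogen: compound 2 and compound 3 fit that reading, and compound 4 goes against it. Nothing available explains this difference. From the compounds shown here alone, whether a matching fused group with oxygen in place of the sulfur would sit with compound 4 or with compound 2 and compound 3 remains open.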